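One Aryl Swap on a Shared Core

The source may report more compounds than this note shows. Statements on the series, on what has been measured and on what is new or still open speak of the compounds shown alone.

Compound 2 `O=C(CSc1nnc(-c2ccncc2)o1)N/N=C/c1ccc([N+](=O)[O-])cc1` shares its core with compound 1 `NNC(=O)CSc1nnc(-c2ccncc2)o1`. Among the measured compounds shown here, in a functional assay on SW 1116 cells (Homo sapiens) for cytotoxicity, read by MTT assay, with a stated time of 48 h (a higher number here means a weaker inhibitor, a lower number a stronger inhibitor), compound 2 gives 25800 nM, the higher of the two numbers measured so far, while compound 1 gives 3260 nM, a gap beyond the usual scatter. Compound 3 `COc1cccc(/C=N/NC(=O)CSc2nnc(-c3ccncc3)o2)c1` keeps the core of compound 2 and differs in one place: 3-methoxyphenyl in place of 4-nitrophenyl on a carbon with a double bond to nitrogen. For the measured compounds named here, no measured pair shows this change, so its size is open; a modest move toward a lower number is expected, though it could stay within the scatter. Compound 3 is expected to give 15000 nM, within 4000 nM to 50000 nM, a step of a 1.7-fold lower number from compound 2 to compound 3 (0.24 log units; within the scatter).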

Compound 3, half-maximal inhibitory concentration: 16500 nM
Beside the measured number, compound 3's estimate is 1.1-fold (0.04 log units) below it, within the range that was stated.
By their numbers in this assay, from the lowest: compound 1; then compounds 3 and 2 (each within the scatter of the next).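

Putting 3-methoxyphenyl in place of 4-nitrophenyl on a carbon with a double bond to nitrogen gives a 1.6-fold lower number from compound 2 to compound 3 (0.19 log units; within the scatter) in this assay. Among the compounds shown here, this is the first step read at this position, and it shows that this particular exchange of one substituted phenyl for another does not move the number beyond the scatter. Nothing on hand explains this result. From the compounds shown here alone, whether an amine or a carboxylic acid on the phenyl ring, or a longer chain in its place, would shift the number beyond the scatter remains open.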